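Aryl exchange toward compound 3 in the cytotoxicity series

The compounds below may be only part of what the source reports. "The series", "measured", "known", "first", "only" and "open" are said of these compounds alone.

Measured so far:
compound 1 `C=CCn1c(=O)/c(=C\c2cc(F)ccc2C)[nH]c(=O)/c1=C\c1ccccc1OC` gives 1800 nM in a functional assay on K562 cells (Homo sapiens) for cytotoxicity, read by CCK-8 assay, with a stated time of 72 h; a higher number here means a weaker inhibitor, a lower number a stronger inhibitor
compound 2 `C=CCn1c(=O)/c(=C\c2cc(OC)c(OC)c(OC)c2)[nH]c(=O)/c1=C\c1cccc(Br)c1` gives "not active" (no number reported) in this assay

Compound 1 carries the only number shown in this assay; compound 2 is recorded without a number, so no comparison of size between the two is possible. Among the compounds with values here, no pair of measured compounds differs in a single place, and no step of this kind has been measured.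

Compound 3 `C=CCn1c(=O)/c(=C\c2ccc(Cl)c(Cl)c2)[nH]c(=O)/c1=C\c1ccccc1OC` differs from compound 1 by 3,4-dichlorophenyl in place of 5-fluoro-2-methylphenyl on a double-bonded chain carbon bound to an aromatic carbon. Both compounds keep the same allyl group and the same methoxyphenyl-bearing part of the shared core.

Within the data shown here, with no measured step to lean on, the expected change from compound 1 to compound 3 is a step of modest size, direction open, estimated as a 1.1-fold higher number from compound 1 to compound 3 (0.05 log units; within the scatter). Compound 3 is therefore expected to give about 2000 nM in this assay, with a range of 600 nM to 7000 nM.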

Compound 3, half-maximal inhibitory concentration: "not active" (no number reported)
For compound 3 the study gives words and no number; no gap can be computed for the estimate.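

In this assay, within the data shown here, compound 1 gives 1800 nM while compound 3 is recorded in words only, so no step between them can be read. The compounds shown leave open how far compound 3 lies from compound 1 in size. No evidence bearing on this result is available.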